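Notes on compound 3 and the untested variant compound 4

A few compounds are considered here, and "the series" means these few. Any claim that something is new, unique, unknown or untested is made for them only; others in the source may bear on it.

Measured in a functional assay on K562/Adr cells (Homo sapiens) for inhibition, read by MTT assay, with a stated time of 48 h, tested at 30 uM; a lower number here means less inhibition, a higher number more inhibition at the concentration tested (going by the name of the read-out):
compound 1 `CC(C)(C)OC(=O)N1C[C@@H](n2cc(-c3ccc4c(N)n[nH]c4c3)nn2)C[C@H]1C(=O)Nc1ccc(Cl)cc1Cl` gives 25.6%
compound 2 `CC(C)(C)OC(=O)N1C[C@@H](n2cc(-c3ccc4nc(N)sc4n3)nn2)C[C@H]1C(=O)Nc1ccc(Cl)c(C(F)(F)F)c1` gives 27.4%
compound 3 `O=C(Nc1nc2ccc(-c3cn([C@@H]4CN[C@H](C(=O)Nc5ccc(Cl)c(C(F)(F)F)c5)C4)nn3)nc2s1)C1CC1` gives 10.4%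

Compound 3 has the lowest of the three numbers in this assay. Its nearest neighbour is compound 1, whose number lies beyond the scatter above it, and compound 2 lies further above it, also beyond the scatter. Compounds 1 and 2 lie within the scatter of each other, so nothing is said of their order. No two of the measured compounds differ in one place only, so no single step can be read from the data.

Compound 4 `O=C(Nc1nc2ccc(-c3cn([C@@H]4CN[C@H](C(=O)Nc5ccc(F)c(F)c5)C4)nn3)nc2s1)C1CC1` is not yet measured in this assay. It differs from compound 3 in one place: 3,4-difluorophenyl in place of 4-chloro-3-(trifluoromethyl)phenyl on an amide-type nitrogen. The rest of the molecule, including the amide-type nitrogen bearing the group and the carbonyl carbon next to it, is unchanged.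

Going by the values given here, with no measured step of this kind to lean on, the expectation for compound 4 is a step of a number 0.4 percentage points lower from compound 3 to compound 4 (within the scatter) that stays within the scatter, with no direction favoured. Compound 4 is therefore estimated at 10%, expected to fall between 0% and 25% in this assay.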

Compound 4, a percentage reported as inhibition, at one concentration (the size of the read-out at that concentration, not a potency): 29.5%
Estimate against measurement, compound 4: 19.5 percentage points below; measured number outside the range, above it.
By their numbers in this assay, from the lowest: compound 3; then compounds 1, 2 and 4 (each within the scatter of the next).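

In this assay, going by these compounds alone, the group on the amide-type nitrogen is the first place where a single change can be read, and the position responds: 3,4-difluorophenyl in place of 4-chloro-3-(trifluoromethyl)phenyl gives a number 19.1 percentage points higher from compound 3 to compound 4 (beyond the scatter). The change takes the group from 11 heavy atoms to 8 and keeps the six-membered aromatic ring of carbon, with 0 hydrogen-bond donors, 0 hydrogen-bond acceptors and no net charge on either side, so the step comes with no difference in those counts. Nothing available bears on why the number moves with this change.

A single step cannot separate the part played by the chlorine, the trifluoromethyl and the two fluorines, and a 4-chlorophenyl or a 3-(trifluoromethyl)phenyl on the same nitrogen would divide that question, while a 4-carboxyphenyl would test a carboxylic acid at this position. Also open, on these data alone, is whether the same exchange gives a similar step in the setting of compound 2, which carries the same 4-chloro-3-(trifluoromethyl)phenyl group on a differently substituted molecule.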